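Aryl exchange on compound 2: notes toward compound 4

This account rests on a few compounds, and the source may have more. Where it says the series, first, only, none or still open, it means among the compounds named here.

Of the compounds shown here, three have been measured in an ADME assay on HFF cells (Homo sapiens) for cytotoxicity, read by MTT assay, with a stated time of 72 h; a higher number here means a weaker inhibitor, a lower number a stronger inhibitor. Compound 1 `O=C1O/C(=C\Cn2cc(-c3ccc(Br)cc3)nn2)C(OCc2ccccc2)=C1OCc1ccccc1` sits at the assay limit of > 100000 nM in this assay. Compound 3 `COc1ccccc1-c1cn(C/C=C2\OC(=O)C(OCc3ccccc3)=C2OCc2ccccc2)nn1` likewise reaches only the limit > 100000 nM. Within the data shown here, compound 2 `COc1ccccc1-c1cn(C[C@H](O)[C@H]2OC(=O)C(OCc3ccccc3)=C2OCc2ccccc2)nn1` gives 50 nM, the only number in the set. Two of the three values are the same limit (the limit of > 100000 nM in this assay, at which 2 of the 3 values shown sit). Among the measured compounds shown here, the single step between measured compounds, a step that the two limits leave unreadable from compound 1 to compound 3, exchanges the aryl group; both its ends are limits and its size is not readable. Compound 4 `Cc1ccc(-c2cn(C[C@H](O)[C@H]3OC(=O)C(OCc4ccccc4)=C3OCc3ccccc3)nn2)cc1` differs from compound 2 by 4-methylphenyl in place of 2-methoxyphenyl on an aromatic carbon. For the measured compounds named here, this is again an aryl exchange, and the one measured aryl step gives no readable size, so no shift beyond the scatter is assumed and the expected step is no change at the digits printed from compound 2 to compound 4 (within the scatter). Compound 4 is therefore estimated at 50 nM, within 15 nM to 200 nM.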

Compound 4, half-maximal inhibitory concentration: > 100000 nM
Compound 4 gave a limit, no number (the forecaster's own chance of this, stated with the estimate: 15%); at least 2000-fold (3.30 log units) between middle value and limit.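

Among these compounds, this aryl position is not neutral: with the rest of the structure unchanged, in this assay 4-methylphenyl in place of 2-methoxyphenyl gives an at least 2000-fold higher number from compound 2 to compound 4 (3.30 log units; beyond the scatter) and is the first readable step. Compound 4 stands at a limit of the assay, not a number. Among the compounds shown here, compound 2 is the only compound off this limit: the limit of > 100000 nM in this assay, at which 3 of the 4 values shown sit.

The step changes both the substituent and its place on the phenyl ring, and the compounds shown do not separate the two. As far as these compounds go, how an unsubstituted phenyl or an aminophenyl group on the same carbon would read remains open.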